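The source may report more compounds than this note shows. Statements on the series, on what has been measured and on what is new or still open speak of the compounds shown alone.

Compound 1 `COc1ccc(/N=N/N2CCCC2)cc1`, 68000 nM
Compound 2 `O=[N+]([O-])c1cccc(/N=N/N2CCCC2)c1`, 66000 nM

Both values come from an ADME assay on MT4 cells (Homo sapiens) for cytotoxicity, read by MTT assay, with a stated time of 96 h (on this read-out higher numbers stand for lower toxicity in this test and lower numbers for higher toxicity in this test), and lie within the usual scatter of each other. Compound 2 therefore stands level with compound 1, and neither can be ranked above the other on these numbers.

The next compound is compound 3 `c1ccc(/N=N/N2CCCC2)cc1`, reached from compound 2 by a single structural change, hydrogen in place of nitro on an aromatic carbon. Among the measured compounds shown here, no measured pair isolates this change, so the data give no direct size for it. For the measured compounds named here, the only guide is the narrow spread of the two known values, with compound 1 at 68000 nM and compound 2 at 66000 nM in the same region. On that basis, no shift beyond the scatter is expected in this assay, in either direction. The expected 1.0-fold lower number from compound 2 to compound 3 (0.01 log units; within the scatter) is accordingly small. For compound 3 the estimated value is 64000 nM, with 28000 nM to 140000 nM as the expected range of the measurement.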

Compound 3, half-maximal cytotoxic concentration: > 100000 nM
Compound 3 gave a limit, no number (the forecaster's own chance of this, stated with the estimate: 15%); at least 1.5-fold (0.19 log units) between middle value and limit.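

Compound 3 carries hydrogen on the aromatic carbon that holds nitro in compound 2. In this assay compound 3 gives > 100000 nM, and this is a limit of the assay and not a number. Hydrogen in place of nitro gives an at least 1.5-fold higher number from compound 2 to compound 3 (0.18 log units; that floor lies within the scatter), and hydrogen in place of methoxy gives an at least 1.4-fold higher number from compound 1 to compound 3 (0.16 log units; that floor lies within the scatter), so the loss of either group brings no lower number, while these floors alone do not establish a step beyond the scatter. The true size of both steps stays unknown because the reading of compound 3 ends at a limit: the limit of > 100000 nM in this assay, at which 1 of the 3 values shown sits.

The compounds shown leave open whether an amine or a carboxylic acid on this aromatic carbon would give a number that differs from those of compound 1 and compound 2 by more than the scatter. They also leave open what a change elsewhere in the shared core would do to the numbers in this assay.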